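The source may report more compounds than this note shows. Statements on the series, on what has been measured and on what is new or still open speak of the compounds shown alone.

In an assay on HEK293 cells for displacement of a labelled ligand from Melanocortin receptor 4 (Homo sapiens) (a higher number here means a weaker inhibitor, a lower number a stronger inhibitor), two compounds share one core and differ only in the group carried on a carbonyl carbon. Compound 1 `CC(C)C[C@H](N)c1cc(C(F)(F)F)ccc1N1CCN(C(=O)CC(C)C(=O)c2ccc(Cl)cc2)CC1` gives 1100 nM. Going by the values given here, compound 2 `Cc1ccc(OCC(=O)N2CCN(c3ccc(C(F)(F)F)cc3[C@@H](N)CC(C)C)CC2)c(C)c1` gives 4000 nM, the highest of the two numbers, and the only step among measured compounds, a 3.6-fold higher number from compound 1 to compound 2 (0.56 log units; beyond the scatter), places compound 2 as the weaker binder of the pair. Compound 3 `COc1ccc(CC(C)C(=O)N2CCN(c3ccc(C(F)(F)F)cc3[C@@H](N)CC(C)C)CC2)cc1` has not been measured; it differs from compound 2 in that (1-(4-methoxybenzyl)ethyl in place of (2,4-dimethylphenoxy)methyl on a carbonyl carbon). Among the compounds with values here, the one measured step that bears on an exchange at this carbonyl carbon is a 3.6-fold higher number from compound 1 to compound 2 (0.56 log units; beyond the scatter), which was modest, so a change at the same place is expected to move this assay by a similarly modest amount, here plausibly back toward compound 1. Compound 3 is therefore expected to give about 2000 nM in this assay, within a range from 700 nM to 6000 nM. This estimate for compound 3 corresponds to an expected step of a 2.0-fold lower number from compound 2 to compound 3 (0.30 log units; within the scatter).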

Compound 3, inhibition constant: 120 nM
Compound 3: the middle estimate sits 17-fold (1.22 log units) above what was measured; the whole stated range lies above it.
By their numbers in this assay, from the lowest: compound 3; then compound 1; then compound 2.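

In this assay, going by these compounds alone, the carbonyl carbon proves far more sensitive than the one earlier step suggested: a 33-fold lower number from compound 2 to compound 3 (1.52 log units; beyond the scatter) is much larger than a 3.6-fold higher number from compound 1 to compound 2 (0.56 log units; beyond the scatter), even though 1-(4-methoxybenzyl)ethyl and (2,4-dimethylphenoxy)methyl are close in heavy-atom count and match in aromatic ring and charge. Within the data shown here, the same group also outperforms the one in compound 1, with a 9.2-fold lower number from compound 1 to compound 3 (0.96 log units; beyond the scatter), leaving compound 3 with the lowest number of the three. Nothing measured here explains why these simple counts fail to predict so large a change.

The exchange alters several features at once, so the compounds shown cannot separate the contribution of the methoxy group from that of the chain carrying the ring. On these data alone, it also remains open whether an amine or a carboxylic acid in place of the methoxy group would preserve this binding.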